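This account rests on a few compounds, and the source may have more. Where it says the series, first, only, none or still open, it means among the compounds named here.

Measured in a functional assay for inhibition, with Homo sapiens as the target; a lower number here means a stronger inhibitor, a higher number a weaker inhibitor:
compound 1 `Cc1cccc(Nc2nccc(-c3cccs3)n2)c1`, 300 nM
compound 2 `Cc1cccc(Nc2nccc(-c3cc(C)oc3C)n2)c1`, 28500 nM
compound 3 `Cc1cccc(Nc2nccc(-c3ccc(C)o3)n2)c1`, 2000 nM

Compound 1 gives the lowest number of the three; compound 3 sits closest to it, a 6.7-fold higher number from compound 1 to compound 3 (0.82 log units; beyond the scatter), and compound 2 furthest, a 95-fold higher number from compound 1 to compound 2 (1.98 log units; beyond the scatter). Compound 4 `c1cc(Nc2nccc(-c3cccs3)n2)cc(OCCn2ccnc2)c1` keeps the thiophen-2-yl of compound 1 and alters only the other ring: 2-(1H-imidazol-1-yl)ethoxy in place of methyl on an aromatic carbon. Going by the values given here, none of the measured steps touches this position; all three exchange the five-membered ring on the shared core, so a 14-fold lower number from compound 2 to compound 3 (1.15 log units; beyond the scatter) and the others give no direct guide. With nothing to anchor the change, a step of modest size in either direction within this assay is the working assumption, with the estimate kept near compound 1. For compound 4 the expected value is 400 nM, range 80 nM to 2500 nM, which means an expected step of a 1.3-fold higher number from compound 1 to compound 4 (0.12 log units; within the scatter).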

Compound 4, half-maximal inhibitory concentration: 100 nM
For compound 4 the middle estimate is 4.0-fold (0.60 log units) above the measured one, within the range that was stated.
By their numbers in this assay, from the lowest: compound 4; then compound 1; then compound 3; then compound 2.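

In this assay, going by these compounds alone, the earlier compounds varied only the five-membered ring on the shared core, whereas compound 4 shows that the other ring also affects the number: 2-(1H-imidazol-1-yl)ethoxy in place of methyl gives a 3.0-fold lower number from compound 1 to compound 4 (0.48 log units; beyond the scatter). This position therefore accepts a group of 8 heavy atoms in place of 1 without loss of inhibition. No available evidence bears on the reason for this step. Open, as far as these compounds go, is whether a longer chain, or a morpholine in place of the imidazole ring, would keep this gain, and whether the same group would give it with 5-methylfuran-2-yl on the core.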